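Changing the Amine Substituent on a Cyclic Sulfonate Core

The compounds below may be only part of what the source reports. "The series", "measured", "known", "first", "only" and "open" are said of these compounds alone.

Measured compounds:
compound 1, `Cc1cn([C@@H]2O[C@H](CO[Si](C)(C)C(C)(C)C)[C@@]3(OS(=O)(=O)C=C3NCC(=O)C(=O)N3CCC3)[C@H]2O[Si](C)(C)C(C)(C)C)c(=O)n(C)c1=O`, gives 17400 nM
compound 2, `COC(=O)CNC1=CS(=O)(=O)O[C@@]12[C@@H](CO[Si](C)(C)C(C)(C)C)O[C@@H](n1cc(C)c(=O)n(C)c1=O)[C@@H]2O[Si](C)(C)C(C)(C)C`, gives 105000 nM

In a functional assay on MT4 cells (Homo sapiens) (on this read-out higher numbers stand for lower toxicity in this test and lower numbers for higher toxicity in this test), compound 2 stands highest of the two numbers; its nearest neighbour is compound 1, and the change a 6.0-fold higher number from compound 1 to compound 2 (0.78 log units; beyond the scatter) lies beyond the scatter. Compound 3, `Cc1cn([C@@H]2O[C@H](CO[Si](C)(C)C(C)(C)C)[C@@]3(OS(=O)(=O)C=C3NC(N)=O)[C@H]2O[Si](C)(C)C(C)(C)C)c(=O)n(C)c1=O`, has not been measured. It differs from compound 2 by carbamoyl in place of (methoxycarbonyl)methyl on an amine nitrogen. Going by the values given here, only one measured step exists, and it alters a different part of the chain than the change to compound 3, so it bears on the new compound only loosely: it shows that a smaller group at this end of the molecule gave a higher number. With so thin a basis, no step beyond the scatter is expected, and compound 3 is estimated to show a 1.3-fold lower number from compound 2 to compound 3 (0.12 log units; within the scatter). Compound 3 is therefore expected to give about 80000 nM, in a range from 30000 nM to 200000 nM.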

Compound 3, half-maximal cytotoxic concentration: 3700 nM
Estimate against measurement, compound 3: 22-fold (1.33 log units) above, and the stated range ends above it.
By their numbers in this assay, from the lowest: compound 3; then compound 1; then compound 2.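

In this assay, the amine nitrogen proves a sensitive place: ureido in place of ((methoxycarbonyl)methyl)amino gives a 28-fold lower number from compound 2 to compound 3 (1.45 log units; beyond the scatter), a change made on the nitrogen itself, whereas the earlier change at the far end of the chain gave a 6.0-fold higher number from compound 1 to compound 2 (0.78 log units; beyond the scatter). The new compound also lies under the one with the longest chain, with a 4.7-fold lower number from compound 1 to compound 3 (0.67 log units; beyond the scatter), so the lowest number sits with carbamoyl, the shortest substituent here, the highest with (methoxycarbonyl)methyl, and substituent length alone does not order the three. Nothing available explains these steps.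

On these data alone, whether an acetyl group or a methyl-substituted urea on this nitrogen would keep the low number remains open. So does what a free amine, or a carboxylic acid in place of the methyl ester, would give.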